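The compounds below may be only part of what the source reports. "The series", "measured", "known", "first", "only" and "open" are said of these compounds alone.

Measured so far:
Compound 1, `CCOC(=O)Nc1sc(-c2ccc(Cl)cc2)c(-c2ccc(Cl)cc2)c1C(=O)NC1CC1`: 27600 nM
Compound 2, `Nc1sc(-c2ccc(Cl)cc2)c(-c2ccc(Cl)cc2)c1C(=O)N1CCOCC1`: 11700 nM

Among the measured compounds shown here, only two compounds have numbers, and both were tested in a functional assay on PC-3 cells (Homo sapiens) for inhibition, read by sulforhodamine B assay, with a stated time of 72 h; on this read-out higher numbers stand for weaker inhibition and lower numbers for stronger inhibition. Compound 2 gives 11700 nM, the lowest of the two numbers; its nearest neighbour is compound 1, whose number is higher by a gap that lies beyond the usual scatter, so compound 2 is the stronger of the two on this read-out, though neither is a potent inhibitor.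

The next compound, compound 3 with the structure `COC(=O)c1c(N)sc(-c2ccc(Cl)cc2)c1-c1ccc(Cl)cc1`, keeps the shared core of compound 2 and differs in one place: methoxy in place of morpholin-4-yl on a carbonyl carbon. The amide attached to the core of compound 2 is thereby replaced by a smaller ester.

For the measured compounds named here, no pair of measured compounds differs in only one place, so there is no reference step to lean on. With so little to go on, the change from compound 2 to compound 3 is expected to leave the number roughly where it is, with a step of a 1.3-fold higher number from compound 2 to compound 3 (0.11 log units; within the scatter) that should stay within or only just beyond the scatter. Compound 3 is therefore estimated at 15000 nM in this assay, with a range from 5000 nM to 50000 nM.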

Compound 3, half-maximal inhibitory concentration: 2780 nM
For compound 3 the middle estimate is 5.4-fold (0.73 log units) above the measured one; the whole stated range lies above it.
By their numbers in this assay, from the lowest: compound 3; then compound 2; then compound 1.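

Among the compounds shown here, at the carbonyl carbon of the shared core, methoxy in place of morpholin-4-yl gives a 4.2-fold lower number from compound 2 to compound 3 (0.62 log units; beyond the scatter) in this assay, a modest change but one beyond the scatter, and the first change in a single place that can be read here. It shows that the group on this carbonyl carbon affects the number, and that in this one pair the smaller group, with no ring and 2 heavy atoms against 6, goes with the stronger inhibition. Whether this comes from the smaller size, the loss of the ring or the change from amide to ester cannot be told from one step, and no measurement bearing on the cause is available.

As far as these compounds go, the two groups are only two points at this position, so it remains open how an ethoxy group, a longer chain on the ester oxygen or a carboxylic acid would read there, and whether a small amine such as methylamine, forming an amide, would match methoxy. From the compounds shown here alone, it is also open whether the same change would hold in a compound carrying the ethyl carbamate of compound 1 instead of the free amino group.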